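Methyl on the Outer Ring of the Shared Core

A few compounds are considered here, and "the series" means these few. Any claim that something is new, unique, unknown or untested is made for them only; others in the source may bear on it.

Three measured compounds share one core and differ only on the outer six-membered ring. Compound 3 `COc1cc(C(=O)c2sc(-c3ccccc3)cc2N)cc(OC)c1OC` carries a bare ring and gives 11 nM in a functional assay on L1210 cells (Mus musculus) for antiproliferative activity; a lower number here means a stronger inhibitor, a higher number a weaker inhibitor. Compound 2 `COc1cc(C(=O)c2sc(-c3ccc([N+](=O)[O-])cc3)cc2N)cc(OC)c1OC` carries a nitro group and gives 100 nM. Compound 1 `COc1cc(C(=O)c2sc(-c3ccc(-c4ccccc4)cc3)cc2N)cc(OC)c1OC` carries a phenyl group and reaches only the assay limit of > 10000 nM (the limit of > 10000 nM in this assay, at which 1 of the 3 values shown sits). Compound 3 therefore holds the lowest of the two numbers, with compound 2 its nearest neighbour. Compound 4 `COc1cc(C(=O)c2sc(-c3ccc(C)cc3)cc2N)cc(OC)c1OC` differs from compound 3 by methyl in place of hydrogen on an aromatic carbon. Among the compounds with values here, two measured steps bear on this: a 9.1-fold lower number from compound 2 to compound 3 (0.96 log units; beyond the scatter) and an at least 900-fold lower number from compound 1 to compound 3 (2.95 log units; beyond the scatter). Each entering group raised the number, the bulkier one far more, so a modest rise is expected for compound 4: a 2.7-fold higher number from compound 3 to compound 4 (0.44 log units; beyond the scatter), an estimate of 30 nM within 8 nM to 150 nM.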

Compound 4, half-maximal inhibitory concentration: 18 nM
The estimate for compound 4 lay 1.7-fold (0.22 log units) above the measured number; the range from low to high includes it.
By their numbers in this assay, from the lowest: compounds 3 and 4 (each within the scatter of the next); then compound 2. At a limit, above all of these: compound 1.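

On this carbon of the outer ring, methyl does not carry the penalty seen with the other two groups: in this assay, the change gives a 1.6-fold higher number from compound 3 to compound 4 (0.21 log units; within the scatter). Replacing either larger group with methyl gives a 5.6-fold lower number from compound 2 to compound 4 (0.74 log units; beyond the scatter) and an at least 550-fold lower number from compound 1 to compound 4 (2.74 log units; beyond the scatter). The step from compound 1 rests on a limit, not a number: the limit of > 10000 nM in this assay, at which 1 of the 4 values shown sits.

From the compounds shown here alone, what an ethyl chain, a methoxy group or an amine would give on this carbon stays open. So does whether methyl on another carbon of this ring would behave the same way.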